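Methylsulfanyl in place of methoxy on compound 3

A few compounds are considered here, and "the series" means these few. Any claim that something is new, unique, unknown or untested is made for them only; others in the source may bear on it.

In a functional assay on the whole organism with Canis familiaris (Canis lupus familiaris) as the target (on this read-out higher numbers stand for an effect only at larger amounts of compound and lower numbers for an effect already at smaller amounts), compound 3 `COc1ccc(-c2cn3ccncc3n2)c(OC)c1` gives 0.7 mg/kg and stands highest of the three measured numbers, with compound 1 `COc1ccc(-c2nc3cc[nH]cc-3n2)c(OC)c1` at 0.3 mg/kg and compound 2 `COc1cc(SC)ccc1-c1nc2cc[nH]cc-2n1` at 0.2 mg/kg on the lower side. Both gaps to compound 3 lie beyond the scatter. The change leading to compound 4 `COc1cc(SC)ccc1-c1cn2ccncc2n1` is methylsulfanyl in place of methoxy on an aromatic carbon. Going by the values given here, one measured step bears on it, the same exchange on the core of compound 1 (a 1.5-fold lower number from compound 1 to compound 2 (0.18 log units; within the scatter)), and that step stays within the scatter. In this assay no step beyond the scatter is therefore expected (a 1.4-fold lower number from compound 3 to compound 4 (0.15 log units; within the scatter)). Compound 4 is estimated at 0.5 mg/kg with an expected range from 0.2 mg/kg to 1.1 mg/kg in this read-out.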

Compound 4, dose for half-maximal effect: 0.5 mg/kg
Compound 4: middle estimate and measured number agree at the digits printed, and the stated range covers the measured number.
By their numbers in this assay, from the lowest: compounds 2, 1, 4 and 3 (each within the scatter of the next, the first and the last beyond it).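

In this assay methylsulfanyl in place of methoxy, para to a group of 9 heavy atoms, gives a 1.4-fold lower number from compound 3 to compound 4 (0.15 log units; within the scatter) on this second core. The exchange at this position therefore reads alike on both cores, with no dependence on the core visible: the same change on two cores in this assay, a 1.5-fold lower number (0.18 log units; within the scatter) from compound 1 to compound 2 and a 1.4-fold lower number (0.15 log units; within the scatter) from compound 3 to compound 4, 1.1-fold (0.03 log units) apart, within the scatter of two such steps.

Both groups compared here carry 2 heavy atoms, so the compounds shown leave open how an amine, a carboxylic acid or a longer chain at this position would read in this assay. Also open, on these data alone, is whether methylsulfanyl in place of the remaining methoxy group would stay equally small.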